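Pyridin-3-yl on the Sulfonamide Nitrogen: an Untested Change

The source may report more compounds than this note shows. Statements on the series, on what has been measured and on what is new or still open speak of the compounds shown alone.

Of the compounds shown here, three have been measured in an assay on CHO cells for displacement of a labelled ligand from prostaglandin E2 receptor EP1 subtype (Homo sapiens); a higher number here means a weaker inhibitor, a lower number a stronger inhibitor. Compound 1 `CCc1ccccc1N(CC(=O)NCc1ccccc1)S(=O)(=O)c1ccc(C)cc1` gives 63.1 nM, compound 2 `CCc1ccccc1N(CC(=O)NCc1cccc(OC)c1)S(=O)(=O)c1ccc(C)cc1` gives 79.4 nM, and compound 3 `CCc1ccccc1N(CC(=O)NCc1ccc(Cl)cc1)S(=O)(=O)c1ccc(C)cc1` gives 10 nM, the lowest number of the three. The steps of a 6.3-fold lower number from compound 1 to compound 3 (0.80 log units; beyond the scatter) and a 7.9-fold lower number from compound 2 to compound 3 (0.90 log units; beyond the scatter) both come from changing the ring on the amide side, while a 1.3-fold higher number from compound 1 to compound 2 (0.10 log units; within the scatter) stays within the scatter. Compound 4 `Cc1ccc(S(=O)(=O)N(CC(=O)NCc2ccc(Cl)cc2)c2cccnc2)cc1` instead alters the other side of the molecule: pyridin-3-yl in place of 2-ethylphenyl on a sulfonamide nitrogen. Going by the values given here, no measured pair changes that group, so these steps give no direct guide, and the expectation rests on little. The estimate for compound 4 is therefore uncertain, placed at 100 nM with a range of 15 nM to 630 nM, which means an expected step of a 10-fold higher number from compound 3 to compound 4 (1.00 log units; beyond the scatter).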

Compound 4, inhibition constant: < 1000 nM
Compound 4: only a limit was reported; the forecaster's own chance of this, stated with the estimate: 5%; the middle value lies beyond the limit too.
By their numbers in this assay, from the lowest: compound 3; then compounds 1 and 2 (each within the scatter of the next).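

Compound 4 gives < 1000 nM, which is a limit of the assay and not a number, so the step from compound 3 to compound 4 cannot be read. The compounds shown leave open how pyridin-3-yl in place of 2-ethylphenyl on a sulfonamide nitrogen changes the number.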